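The compounds below may be only part of what the source reports. "The series", "measured", "known", "first", "only" and "open" are said of these compounds alone.

Measured compounds:
compound 1 `Nc1nc(N)c2c(-c3ccsc3)cn([C@@H]3O[C@H](CO)[C@@H](O)[C@H]3O)c2n1`, > 100000 nM
compound 2 `Cc1ncnc2c1c(I)cn2[C@@H]1O[C@H](CO)[C@@H](O)[C@H]1O`, 12200 nM
compound 3 `Nc1nc2c(c(-c3ccco3)cn2[C@@H]2O[C@H](CO)[C@@H](O)[C@H]2O)c(=O)[nH]1`, > 20000 nM

Three nucleoside analogues sharing a ribose unit have been tested in a functional assay on A549 cells (Homo sapiens), read by MTT assay, with a stated time of 72 h; on this read-out lower numbers stand for stronger inhibition and higher numbers for weaker inhibition. Compound 1, `Nc1nc(N)c2c(-c3ccsc3)cn([C@@H]3O[C@H](CO)[C@@H](O)[C@H]3O)c2n1`, reached only a limit of this assay, > 100000 nM. Compound 3, `Nc1nc2c(c(-c3ccco3)cn2[C@@H]2O[C@H](CO)[C@@H](O)[C@H]2O)c(=O)[nH]1`, likewise gave only a limit, > 20000 nM. Among the measured compounds shown here, compound 2, `Cc1ncnc2c1c(I)cn2[C@@H]1O[C@H](CO)[C@@H](O)[C@H]1O`, is the one compound for which this assay returns a number, 12200 nM. The result of compound 1 is the limit of > 100000 nM in this assay, at which 1 of the 3 values shown sits. The result of compound 3 is the limit of > 20000 nM in this assay, at which 1 of the 3 values shown sits. Compound 2 therefore stands alone as the sole quantified point.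

Compound 4, `Cc1ncnc2c1c(-c1cccs1)cn2[C@@H]1O[C@H](CO)[C@@H](O)[C@H]1O`, has not yet been measured in this assay. It differs from compound 2 in one place: thiophen-2-yl in place of iodo on an aromatic carbon. For the measured compounds named here, no pair among the measured compounds differs in a single place, so there is no measured step to set the scale of this change. Compound 1 and compound 3 also carry a five-membered aromatic ring on the shared core, but each differs from compound 2 in further places as well and each sits at a limit, so they cannot settle the matter.

The step from compound 2 to compound 4 is expected to be an 8.1-fold lower number from compound 2 to compound 4 (0.91 log units; beyond the scatter), towards stronger inhibition and beyond the usual scatter. Compound 4 is accordingly estimated at 1500 nM, with a range from 200 nM to 10000 nM.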

Compound 4, half-maximal inhibitory concentration: > 20000 nM
Compound 4 was reported as a limit (the forecaster's own chance of this, stated with the estimate: 10%); at least 13-fold (1.12 log units) between middle value and limit.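

In this assay, among the compounds shown here, putting thiophen-2-yl in place of iodo on this aromatic carbon gives an at least 1.6-fold higher number from compound 2 to compound 4 (0.21 log units; that floor lies within the scatter), and this is the first measured step at this position. Compound 4 ends at a limit and not a number, the same limit that compound 3 reached: the limit of > 20000 nM in this assay, at which 2 of the 4 values shown sit. On this change alone, then, the five-membered aromatic ring brings no gain in inhibition over the iodo group, although the floor of the step does not establish a loss beyond the usual scatter.

The compounds shown leave open how far the true value of compound 4 lies from that of compound 2, so the full size of this step remains unknown. They also leave open whether a different group on this aromatic carbon, such as an amine, a nitrile or a phenyl ring, would keep the inhibition seen with iodo or move it in either direction.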